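The source may report more compounds than this note shows. Statements on the series, on what has been measured and on what is new or still open speak of the compounds shown alone.

The account starts from compound 1 `S=C(NCc1cccnc1)SCCc1nnc(-c2ccccc2)o1`. In a functional assay on MDA-MB-468 cells (Homo sapiens) for cytotoxicity, read by resazurin assay, with a stated time of 72 h (on this read-out lower numbers stand for stronger inhibition and higher numbers for weaker inhibition), compound 1 gives 2770 nM, the lowest of the two numbers in hand. Among the compounds with values here, its only measured companion is compound 2 `S=C(NCc1cccnc1)SCCc1nnc(-c2ccc3ccccc3n2)o1`, which in this assay gives 3500 nM; the two values lie within the usual scatter of each other, so nothing can be read into their order. Within the data shown here, no step between measured compounds that differ in a single place is available, and no pattern can be drawn from two numbers that do not separate. The step followed here leads from compound 1 to the unmeasured compound 3 `S=C(NCc1cccnc1)SCCc1nnc(-c2cc3ccccc3s2)o1`. The change is 1-benzothiophen-2-yl in place of phenyl on an aromatic carbon. Among the measured compounds shown here, the record shows only that phenyl and the group of compound 2 at this place give numbers within scatter of each other, which is thin ground for the present exchange. The estimated step in this assay is a 1.1-fold higher number from compound 1 to compound 3 (0.03 log units; within the scatter), nothing beyond the scatter in either direction. Compound 3 is accordingly estimated at 3000 nM, with an expected range from 1000 nM to 9000 nM.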

Compound 3, half-maximal inhibitory concentration: 6770 nM
Compound 3: middle estimate off by 2.3-fold (0.35 log units), on the low side; low and high end bracket the measured number.
By their numbers in this assay, from the lowest: compounds 1, 2 and 3 (each within the scatter of the next, the first and the last beyond it).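

In this assay, 1-benzothiophen-2-yl in place of phenyl gives a 2.4-fold higher number from compound 1 to compound 3 (0.39 log units; beyond the scatter), a modest step, but the only one at this place on the five-membered aromatic ring that lies beyond the scatter. The place is therefore not indifferent to the group it carries, which the earlier pair could not show, yet the change does not separate the two larger-numbered compounds: compound 2 at 3500 nM and compound 3 at 6770 nM remain within the scatter of each other, and compound 2 also remains within the scatter of compound 1. No measurement available here bears on the reason for this step.

The entering group differs from phenyl in both its added ring and its ring sulfur, and the compounds shown do not separate these two differences. They also leave open how this place would respond to a much smaller group such as methyl, or to a phenyl carrying an amine or a carboxylic acid, and whether a longer chain in the core of compound 1 would alter the step.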